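The source may report more compounds than this note shows. Statements on the series, on what has been measured and on what is new or still open speak of the compounds shown alone.

Compound 3 `CCOc1ccc2nc(C(=O)Nc3c(F)cc(-c4cccc(F)c4)cc3F)c(C)c(C(=O)O)c2c1` gives 2.06% in a functional assay on Hep 3B2 cells (Homo sapiens) for antiproliferative activity, read by MTT assay, with a stated time of 24 h, tested at 0.14 ug/mL; a lower number here means a weaker effect, a higher number a stronger effect of the compound at the concentration tested. This is the largest of the three numbers shown, yet the gaps are small: compound 1 `CCc1ccc2nc(C(=O)Nc3c(F)cc(-c4cccc(F)c4)cc3F)c(C)c(C(=O)O)c2c1` gives 0.68% and compound 2 `Cc1c(C(=O)Nc2c(F)cc(-c3cccc(F)c3)cc2F)nc2ccc(F)cc2c1C(=O)O` gives 0.65%, so that a number 1.4 percentage points higher from compound 1 to compound 3 (within the scatter) and a number 1.4 percentage points higher from compound 2 to compound 3 (within the scatter) stay within the scatter, as does a number 0 percentage points lower from compound 1 to compound 2 (within the scatter). Compound 4 `COc1ccc2nc(C(=O)Nc3c(F)cc(-c4cccc(F)c4)cc3F)c(C)c(C(=O)O)c2c1` differs from compound 3 by hydrogen in place of methyl on a saturated chain carbon bound to an oxygen on an aromatic ring. For the measured compounds named here, no measured step covers this change; the steps that touch the same aromatic carbon all stayed within the scatter, so the gap from compound 3 to compound 4 is expected to stay within the scatter too, as a number 0.6 percentage points lower from compound 3 to compound 4 (within the scatter). Compound 4 is therefore estimated at 1.5%, in the range 0% to 6%.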

Compound 4, a percentage reported as inhibition, at one concentration (the size of the read-out at that concentration, not a potency): 0.02%
For compound 4 the middle estimate is 1.5 percentage points above the measured one; measured number inside the range.
By their numbers in this assay, from the lowest: compounds 4, 2, 1 and 3 (each within the scatter of the next).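

In this assay, the change now reaches the chain itself rather than only the group on the aromatic carbon, and going from ethoxy to methoxy stays within the scatter (a number 2 percentage points lower from compound 3 to compound 4 (within the scatter)). Methoxy also cannot be told apart from fluoro (a number 0.6 percentage points lower from compound 2 to compound 4 (within the scatter)) or ethyl (a number 0.7 percentage points lower from compound 1 to compound 4 (within the scatter)), so none of these four groups separates from the others at this position. No evidence available here bears on this result. Going by these compounds, what remains open is whether an amine, a carboxylic acid or a longer chain such as propoxy on this aromatic carbon would give a step beyond the scatter.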